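The source may hold more compounds than are shown below. What is called first, only, known or untested is meant among the compounds shown, and "the series" means these compounds.

Measured so far in a functional assay on HepG2 cells (Homo sapiens) for cytotoxicity, with a stated time of 72 h; a lower number here means that less compound is needed, a higher number that more compound is needed for the effect:
- Compound 1 `C=C[C@@](C)(/C=C/c1ccc(OS(=O)(=O)C(F)(F)F)cc1)CCC=C(C)C`: > 52000 nM
- Compound 2 `C=C[C@@](C)(/C=C/c1ccc(OS(=O)(=O)c2ccc(C)cc2)cc1)CCC=C(C)C`: > 52000 nM
- Compound 3 `C=C[C@@](C)(/C=C/c1ccc(O)cc1)CCC(O)C(C)(C)O`: > 52000 nM

Each of these entries is a limit of the assay and not a number. Compound 3 gives > 52000 nM, which is such a limit. It therefore has no exact position among the compounds, and the other two stand at the same limit: the limit of > 52000 nM in this assay, at which 3 of the 3 values shown sit.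

Compound 4 `C=C[C@@](C)(/C=C/c1ccc(O)cc1)CC/C=C(C)/C=N/N` differs from compound 3 in one part of the chain: a group of 6 heavy atoms (4 carbon, 2 nitrogen; no ring) in place of a group of 6 heavy atoms (4 carbon, 2 oxygen; no ring), on a saturated chain carbon, three bonds along the chain from two double-bonded chain carbons. The 1,2-dihydroxy-2-methylpropyl group leaves, and a group of the same heavy-atom count, holding nitrogen instead of oxygen, enters.

Going by the values given here, the only measured step is a step that the two limits leave unreadable from compound 1 to compound 2. It concerns a group on a sulfonyl sulfur, a different change from this one, and gives no size to carry over. Among the compounds with values here, no measured step therefore predicts a change in either direction in this assay, and none beyond the scatter is expected. The best guide is compound 3, with its limit of > 52000 nM.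

For compound 4 the estimate is 52000 nM, with an expected range from 20000 nM to 100000 nM. This estimate means an expected a number no higher from compound 3 to compound 4 (the limit leaves the size open). Compound 4 is most likely to be reported as a limit too, although the lower end of the range leaves room for a measurable number.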

Compound 4, half-maximal effective concentration: > 52000 nM
Compound 4: only a limit was reported (the forecaster's own chance of this, stated with the estimate: 70%); the middle value sits exactly at the limit.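

In this assay, compound 3 and compound 4 are both reported only as limits and not as numbers, so the step between them cannot be read. All the compounds shown share one result: the limit of > 52000 nM in this assay, at which 4 of the 4 values shown sit. As far as these compounds go, it remains open how far each compound lies beyond that limit, and whether any structural change would give a measurable number.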